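The source may report more compounds than this note shows. Statements on the series, on what has been measured and on what is new or still open speak of the compounds shown alone.

Compound 3 `CCCCCCCCCCCCCCCCCCNC(=O)[C@@H](NC(=O)c1cc2ccccc2[nH]1)[C@@H](C)O` gives the lowest of the two numbers in a functional assay on SW-620 cells (Homo sapiens) for cytotoxicity, read by MTT assay, with a stated time of 48 h (on this read-out lower numbers stand for stronger inhibition and higher numbers for weaker inhibition), at 23600 nM. Compound 2 `CCCCCCCCCCCCCCCCCCNC(=O)[C@@H](NC(=O)c1cccs1)[C@@H](C)O` gives 200000 nM in this assay. Compound 1 `CCCCCCCCCCCCCCCCCCNC(=O)[C@@H](NC(=O)c1ccco1)[C@@H](C)O` reaches only the limit of > 200000 nM in this assay, which is a limit of the measurement rather than a number (the limit of > 200000 nM in this assay, at which 1 of the 3 values shown sits). Compound 4 `CCCCCCCCCCCCCCCCCCNC(=O)[C@@H](NS(=O)(=O)c1ccc(C)cc1)[C@@H](C)O` carries the change ((4-methylphenyl)sulfonyl in place of (1H-indol-2-yl)carbonyl on an amine nitrogen). Going by the values given here, no measured step swaps a carbonyl for a sulfonyl; the steps that bear on it replace the indol-2-yl by smaller aromatic groups and run the other way: an 8.5-fold lower number from compound 2 to compound 3 (0.93 log units; beyond the scatter) and an at least 8.4-fold lower number from compound 1 to compound 3 (0.92 log units; beyond the scatter). Leaving the indol-2-yl is therefore expected to raise the number in this assay, with an estimated step of a 6.4-fold higher number from compound 3 to compound 4 (0.80 log units; beyond the scatter). For compound 4 the estimate is 150000 nM, with a range from 50000 nM to 300000 nM.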

Compound 4, half-maximal inhibitory concentration: 32500 nM
The estimate for compound 4 lay 4.6-fold (0.66 log units) above the measured number, and the stated range ends above it.
By their numbers in this assay, from the lowest: compounds 3 and 4 (each within the scatter of the next); then compound 2.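

At this amine nitrogen in this assay, a carbonyl is not required: the (4-methylphenyl)sulfonyl group stays level with the (1H-indol-2-yl)carbonyl (a 1.4-fold higher number from compound 3 to compound 4 (0.14 log units; within the scatter)). The sulfonyl compound also reads clearly lower than the thiophene amide (a 6.2-fold lower number from compound 2 to compound 4 (0.79 log units; beyond the scatter)) and the furan amide (an at least 6.1-fold lower number from compound 1 to compound 4 (0.78 log units; beyond the scatter)), so the lower number is not tied to the indol-2-yl alone. Compound 1 stands at a limit, not a number: (the limit of > 200000 nM in this assay, at which 1 of the 4 values shown sits).

Open, on these data alone, is whether the sulfonyl linker or the methylphenyl ring carries this reading. A methanesulfonyl group or a shorter chain would bear on that.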